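Benzyl for methyl on a purine-type core: an expectation

The source may report more compounds than this note shows. Statements on the series, on what has been measured and on what is new or still open speak of the compounds shown alone.

Compound 2, `Cn1cnc2c(Sc3ccc(F)cc3)ncnc21`, was assayed in an assay on isolated protein for inhibition of RAC-alpha serine/threonine-protein kinase (Homo sapiens), tested at 30 uM (on this read-out higher numbers stand for more inhibition at the one concentration tested (going by the name of the read-out) and lower numbers for less inhibition), where compound 2 gives 0%. Compound 1, `Cn1cnc2c(Sc3ccccc3)ncnc21`, the parent without the fluoro group, gives 0%; the step of no change at the digits printed from compound 1 to compound 2 (within the scatter). Compound 3, `Cn1c(-c2ccc([S+](C)[O-])cc2)nc2c(Sc3ccc(F)cc3)ncnc21`, gives 10%, and the step of a number 10 percentage points higher from compound 2 to compound 3 (within the scatter). On these numbers compound 2 stands level with compound 1 and together they are the lowest of the three, with compound 3 a shade higher but within the scatter.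

Compound 4, `Fc1ccc(Sc2ncnc3c2ncn3Cc2ccccc2)cc1`, differs from compound 2 in one place: phenyl in place of hydrogen on a saturated chain carbon bound to an aromatic nitrogen. Cut one bond further out, the same difference reads methyl to benzyl. Within the data shown here, no measured step touches this position; the two steps at hand, fluoro for hydrogen and the nine-heavy-atom group for hydrogen, both stayed within the scatter, and the whole series sits at or near no inhibition. The expected step is therefore a number 3 percentage points higher from compound 2 to compound 4 (within the scatter), none beyond the scatter. Compound 4 is estimated at 3%, with a range from -8% to 18%.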

Compound 4, a percentage reported as inhibition, at one concentration (the size of the read-out at that concentration, not a potency): 1%
Compound 4: middle estimate off by 2 percentage points, on the high side; low and high end bracket the measured number.
By their numbers in this assay, from the lowest: compounds 1, 2, 4 and 3 (each within the scatter of the next).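

Among these compounds, with this step the saturated chain carbon bound to an aromatic nitrogen comes into view for the first time: in this assay, the change of methyl to benzyl gives a number 1 percentage points higher from compound 2 to compound 4 (within the scatter). A phenyl of six heavy atoms on that carbon therefore moves the read-out no further than the scatter, and since compound 2 already gives 0%, a loss at this position could not have shown on this read-out. Nothing available explains this result.

The compounds shown leave open whether an amine, a carboxylic acid or a longer chain on that carbon would give a number beyond the scatter. They also leave open whether benzyl at this place would read differently on a compound that also carries the aromatic group of compound 3.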